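This account rests on a few compounds, and the source may have more. Where it says the series, first, only, none or still open, it means among the compounds named here.

Measured in a functional assay on HCT-116 cells (Homo sapiens) for antiproliferative activity, read by MTT assay; a higher number here means a weaker inhibitor, a lower number a stronger inhibitor:
- compound 1 `Cn1c(=O)c(=O)n(C2CCCC2)c2nc(N/N=C/c3ccccc3)ncc21`: > 100000 nM
- compound 2 `CSc1ccc(/C=N/Nc2ncc3c(n2)n(C2CCCC2)c(=O)c(=O)n3C)cc1`: 9010 nM

The entry for compound 1 is a limit. Within the data shown here, that leaves compound 2, at 9010 nM, as the only actual number in this assay so far.

The next compound is compound 3 `Cn1c(=O)c(=O)n(C2CCCC2)c2nc(N/N=C/c3ccc(OC(F)(F)F)cc3)ncc21`, which carries trifluoromethoxy in place of methylsulfanyl on an aromatic carbon, para to a large group: trifluoromethoxy in place of methylsulfanyl on an aromatic carbon.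

Among the measured compounds shown here, one measured step bears on this change, and it is large: an at least 11-fold lower number from compound 1 to compound 2 (1.04 log units; beyond the scatter). It shows that filling this place with methylsulfanyl instead of hydrogen can shift the number strongly. However, it starts from a limit and compares a group with hydrogen, not one group with another. For the measured compounds named here, no measurement yet separates two groups at this carbon. Compound 3 keeps a group there, so a return towards compound 1 is not the expectation.

The estimated change is a 1.1-fold higher number from compound 2 to compound 3 (0.05 log units; within the scatter), and no shift beyond the scatter is expected, though the uncertainty is wide. For compound 3 the expected value is 10000 nM, within an estimated range of 3000 nM to 35000 nM.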

Compound 3, half-maximal inhibitory concentration: 6150 nM
For compound 3 the middle estimate is 1.6-fold (0.21 log units) above the measured one; measured number inside the range.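

Among these compounds, this is the first comparison of two groups at this aromatic carbon. In this assay there is a 1.5-fold lower number from compound 2 to compound 3 (0.17 log units; within the scatter), so the compounds shown do not separate trifluoromethoxy from methylsulfanyl at this place, para to a large group. A second group now also stands against hydrogen, with an at least 16-fold lower number from compound 1 to compound 3 (1.21 log units; beyond the scatter), so the large shift is not tied to methylsulfanyl or to its sulfur, as both substituted compounds sit well clear of compound 1. The steps from compound 1 start from a limit, and their full size stays unknown: the limit of > 100000 nM in this assay, at which 1 of the 3 values shown sits.

Still open, on these data alone, is whether any group at this carbon can move the number beyond the scatter from compound 2 and compound 3, which an amine, a carboxylic acid or a longer alkyl chain would test. Both groups also sit para to a large group, leaving open how the same groups would read on another carbon of this ring.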